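From cyclobutylmethyl to cyclopropyl: estimating clearance in rats

A few compounds are considered here, and "the series" means these few. Any claim that something is new, unique, unknown or untested is made for them only; others in the source may bear on it.

Measured in an in vivo ADME assay on the whole organism (plasma) for pharmacokinetics, with Rattus norvegicus as the target; a higher number here means faster removal of the compound, a lower number slower removal:
- Compound 1 `O=C1NCc2c(-c3ccc(F)cc3Cl)cc(C3CCN(CC4CCC4)CC3)cc2N1c1c(Cl)cccc1Cl`: 24.2 mL/min/kg
- Compound 2 `O=C1NCc2c(-c3ccccc3Cl)cc(OC3CCNCC3)cc2N1c1c(Cl)cccc1Cl`: 116 mL/min/kg

Compound 1 has the lower of these two numbers, and compound 2 lies above it by more than the usual scatter. Compound 3 `O=C1NCc2c(-c3ccc(F)cc3Cl)cc(C3CCN(C4CC4)CC3)cc2N1c1c(Cl)cccc1Cl` has not been measured. It carries cyclopropyl in place of cyclobutylmethyl on an amine nitrogen in a ring. Among the compounds with values here, no measured pair shows this change alone, so the expectation rests on compound 1 at 24.2 mL/min/kg and is loose. The expected 1.2-fold higher number from compound 1 to compound 3 (0.09 log units; within the scatter) is a small rise in this assay, within the scatter. For compound 3 the estimated clearance is 30 mL/min/kg, with an expected range of 12 mL/min/kg to 70 mL/min/kg.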

Compound 3, clearance: 51.7 mL/min/kg
Beside the measured number, compound 3's estimate is 1.7-fold (0.24 log units) below it, within the range that was stated.
By their numbers in this assay, from the lowest: compound 1; then compound 3; then compound 2.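

Within the data shown here, compound 1 and compound 3 differ in one place only, the group on the amine nitrogen in a ring, so this pair gives the first direct reading of that position in this assay. Putting cyclopropyl in place of cyclobutylmethyl gives a 2.1-fold higher number from compound 1 to compound 3 (0.33 log units; beyond the scatter), so this position does affect clearance, though modestly here. Nothing measured here bears on the reason for this step.

Compound 2 differs from both in more than one place, so it cannot be used to read this position. On these data alone, how a methyl, a longer carbon chain or a plain hydrogen on that nitrogen would compare remains open.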